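The source may report more compounds than this note shows. Statements on the series, on what has been measured and on what is new or still open speak of the compounds shown alone.

Compound 1, with the structure `CCCCNc1ccc(C(=O)N2CCCCc3ccccc32)c(Cl)c1`, is one of two compounds for which a number is known in an assay on HeLa cells for binding affinity to Vasopressin V2 receptor (Homo sapiens); on this read-out higher numbers stand for weaker inhibition and lower numbers for stronger inhibition. In this assay compound 1 gives 22 nM. Compound 2, with the structure `O=C(c1ccc(-n2cccc2)cc1)N1CCCCc2ccccc21`, is the other; in this assay compound 2 gives 320 nM. Of the two numbers, that of compound 1 is the lower, and the gap to compound 2 is wider than the usual scatter, so compound 1 stands as the stronger of the pair on this read-out.

Compound 3, with the structure `O=C(c1ccc(-n2cccn2)cc1Cl)N1CCCCc2ccccc21`, has not yet been measured in this assay. It differs from compound 1 in one place: 1H-pyrazol-1-yl in place of butylamino on an aromatic carbon. The chloro group that compound 1 carries is kept, while the butylamino chain gives way to a five-membered aromatic ring. Among the measured compounds shown here, no measured pair shows this exact exchange, so the expectation rests on the two known numbers alone. Compound 2, which carries an aromatic nitrogen ring at the corresponding place and lacks the chloro group, gives 320 nM, a weaker result than compound 1. It is therefore expected that the step from compound 1 to compound 3 is upward, toward weaker binding, at a 6.8-fold higher number from compound 1 to compound 3 (0.83 log units; beyond the scatter), a step beyond the scatter. For compound 3 an estimate of 150 nM is given, with a range from 40 nM to 600 nM.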

Compound 3, half-maximal inhibitory concentration: 8.8 nM
The estimate for compound 3 lay 17-fold (1.23 log units) above the measured number; the whole stated range lies above it.
By their numbers in this assay, from the lowest: compound 3; then compound 1; then compound 2.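

In this assay, the place on the aromatic ring that lies para to a large group and meta to the chloro group accepts a five-membered aromatic ring in place of an open chain, and the exchange gives a 2.5-fold lower number from compound 1 to compound 3 (0.40 log units; beyond the scatter) as a modest step. Among the compounds shown here, with the chloro group and the rest of the core of compound 1 kept, this is the first change at this place that can be read on its own, since compound 2 differs from both other compounds in more than one place, and it shows that neither the butylamino chain nor its hydrogen-bond donor is required for a low number on this read-out. Nothing at hand accounts for the drop in the number.

The share of the chloro group and of the second ring nitrogen of 1H-pyrazol-1-yl in this result stays open, as no pair shown isolates either of them. Equally open, going by these compounds, is how a 1H-imidazol-1-yl group, a pyridyl ring or a longer chain such as hexylamino would fare at this place.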